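The compounds below may be only part of what the source reports. "The series", "measured", "known", "first", "only" and "open" are said of these compounds alone.

Measured in an ADME assay on BJ cells (Homo sapiens) for cytotoxicity, with a stated time of 72 h; a lower number here means that less compound is needed, a higher number that more compound is needed for the effect (all three values are limits, not numbers)
Compound 1 `CCc1ccc(-c2nc3c(c(C)nn3-c3ccccc3)c(-c3ccccc3O)c2C#N)cc1` gives > 20000 nM
Compound 2 `CCc1ccc(-c2nc3c(c(C)nn3-c3ccccc3)c(-c3ccccc3I)c2C#N)cc1` gives > 20000 nM
Compound 3 `Cc1nn(-c2ccccc2)c2nc(-c3ccc4c(c3)OCCO4)c(C#N)c(-c3ccccc3O)c12` gives > 20000 nM

Compound 1 stands at a limit (> 20000 nM) and has no number. All measured compounds share that position (the limit of > 20000 nM in this assay, at which 3 of the 3 values shown sit). Compound 4 `CCc1ccc(-c2nc3c(c(C4CC4)nn3-c3ccccc3)c(-c3ccccc3O)c2C#N)cc1` carries cyclopropyl in place of methyl on an aromatic carbon. The measured changes lie elsewhere and offer only a step that the two limits leave unreadable from compound 1 to compound 2 and a step that the two limits leave unreadable from compound 1 to compound 3 as guidance, so no size carries over. In this assay compound 1 gives > 20000 nM as a limit, and no large step is expected from it. The expected outcome is a number no higher from compound 1 to compound 4 (the limit leaves the size open) as an estimate. For compound 4 the estimate is 20000 nM with an expected range of 9000 nM to 40000 nM and a limit is the likeliest report.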

Compound 4, half-maximal effective concentration: > 20000 nM
Compound 4 ended at the assay's limit (the forecaster's own chance of this, stated with the estimate: 80%); the middle value sits exactly at the limit.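

Compound 1 and compound 4 both report only a limit, so no step can be read between them: the limit of > 20000 nM in this assay, at which 4 of the 4 values shown sit.

The compounds shown leave open how large the change from methyl to cyclopropyl is, and which change in this series would give a number.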